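Notes on replacing 2-hydroxynaphthalen-1-yl with phenyl

The source may hold more compounds than are shown below. What is called first, only, known or untested is meant among the compounds shown, and "the series" means these compounds.

Values in a functional assay on MGC-803 cells (Homo sapiens) for antiproliferative activity, read by MTT assay, with a stated time of 72 h; on this read-out higher numbers stand for weaker inhibition and lower numbers for stronger inhibition
compound 1 `CCCSc1nc(N/N=C(\C)c2ccc(O)cc2)c2nnn(Cc3ccccc3)c2n1` gives 16700 nM
compound 2 `CCCSc1nc(N/N=C/c2cccc(Cl)c2)c2nnn(Cc3ccccc3)c2n1` gives > 64000 nM (a limit of the assay)
compound 3 `CCCSc1nc(N/N=C/c2c(O)ccc3ccccc23)c2nnn(Cc3ccccc3)c2n1` gives 3710 nM

Compound 3 at 3710 nM holds the lower of the two true numbers, and compound 1 stands at 16700 nM by comparison. Compound 2 reports only a limit, > 64000 nM in this series.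

Compound 4 `CCCSc1nc(N/N=C/c2ccccc2)c2nnn(Cc3ccccc3)c2n1` is still unmeasured. Its difference from compound 3 is phenyl in place of 2-hydroxynaphthalen-1-yl on a carbon with a double bond to nitrogen.

The closest evidence is an at least 17-fold lower number from compound 2 to compound 3 (1.23 log units; beyond the scatter) where 2-hydroxynaphthalen-1-yl replaced 3-chlorophenyl at the same place. Also relevant is an at least 3.8-fold higher number from compound 1 to compound 2 (0.58 log units; beyond the scatter) although that step changes more than the ring substituent. Within the data shown here, no measured step isolates plain phenyl, so only part of the large step is expected to reverse, and the direction expected is towards a higher number. The expected change is an 8.1-fold higher number from compound 3 to compound 4 (0.91 log units; beyond the scatter) in this assay for this replacement. The estimated value for compound 4 is 30000 nM with an expected range from 10000 nM to 80000 nM in this assay.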

Compound 4, half-maximal inhibitory concentration: > 64000 nM
Compound 4: a limit, no number; the forecaster's own chance of this, stated with the estimate: 35%; middle value at least 2.1-fold (0.32 log units) from the limit.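

In this assay, the change to phenyl on the carbon with a double bond to nitrogen gives an at least 17-fold higher number from compound 3 to compound 4 (1.23 log units; beyond the scatter), so the activity seen with 2-hydroxynaphthalen-1-yl is not retained with an unsubstituted phenyl ring. A second step points the same way, an at least 3.8-fold higher number from compound 1 to compound 4 (0.58 log units; beyond the scatter), although it changes more than one feature of the group. Compound 4 gives > 64000 nM, a limit and not a number, and the step that joins it to the other compound at this limit cannot be read: the limit of > 64000 nM in this assay, at which 2 of the 4 values shown sit.

The compounds shown do not separate the contribution of the hydroxyl from that of the second aromatic ring within 2-hydroxynaphthalen-1-yl. Naphthalen-1-yl and 2-hydroxyphenyl at this place would divide the two, and an amine in place of the hydroxyl would test whether oxygen is required.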